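Aryl swap on the shared core: what compound 3 may give

The compounds below may be only part of what the source reports. "The series", "measured", "known", "first", "only" and "open" are said of these compounds alone.

Working notes on the series. Going by the values given here, compound 1 `Fc1ccc(C2=NN(C(=S)Nc3ccccc3)C(c3ccc4c(c3)OCCO4)C2)cc1` is the only compound with a number in a functional assay on A-375 cells (Homo sapiens) for antiproliferative activity, read by MTT assay, with a stated time of 48 h; a higher number here means a weaker inhibitor of growth, a lower number a stronger inhibitor of growth; in this assay compound 1 gives 15700 nM. Compound 2 `S=C(Nc1ccccc1)N1N=C(c2cccc(Cl)c2)CC1c1ccc2c(c1)OCCO2` reaches only a limit of this assay, > 200000 nM. Among the compounds with values here, the one measured step, an at least 12-fold higher number from compound 1 to compound 2 (1.10 log units; beyond the scatter), is open-ended in size due to the limit of > 200000 nM in this assay, at which 1 of the 2 values shown sits. Compound 3 `COc1cccc(C2=NN(C(=S)Nc3ccccc3)C(c3ccc4c(c3)OCCO4)C2)c1` differs from compound 1 by 3-methoxyphenyl in place of 4-fluorophenyl on a carbon with a double bond to nitrogen, a change at the same place as the measured step, so a weakening beyond the scatter is expected, a 3.8-fold higher number from compound 1 to compound 3 (0.58 log units; beyond the scatter), possibly smaller than the measured step. Compound 3 is estimated at 60000 nM, in a range from 15000 nM to 200000 nM.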

Compound 3, concentration for 50% growth inhibition: 520 nM
The estimate for compound 3 lay 120-fold (2.06 log units) above the measured number; measured number below the stated range.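

This place on the carbon with a double bond to nitrogen can also strengthen growth inhibition in this assay: 3-methoxyphenyl in place of 4-fluorophenyl gives a 30-fold lower number from compound 1 to compound 3 (1.48 log units; beyond the scatter). Methoxy in place of chloro on an aromatic carbon gives an at least 380-fold lower number from compound 2 to compound 3 (2.58 log units; beyond the scatter), a step open-ended in size: the limit of > 200000 nM in this assay, at which 1 of the 3 values shown sits. The steps from compound 1 at this place therefore run in both directions.

The compounds shown do not separate the effect of the methoxy group from that of its place on the phenyl ring. From the compounds shown here alone, how an ethoxy group or an amine would behave there also stays open.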